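Replacing the isoquinoline of compound 2 with a nitrogen-bearing fused ring

This account rests on a few compounds, and the source may have more. Where it says the series, first, only, none or still open, it means among the compounds named here.

Compound 2 `O=C(Nc1cncc2ccccc12)N1CCN(Cc2cccc(Oc3ccc(Cl)cc3)c2)CC1` gives 6.7 nM in an assay on isolated protein for inhibition of Fatty-acid amide hydrolase 1 (Homo sapiens), with a stated time of 60 min (a higher number here means a weaker inhibitor, a lower number a stronger inhibitor), the lowest number among the three compounds measured, with compound 3 `O=C(Nc1noc2ccccc12)N1CCN(Cc2cccc(Oc3ccc(Cl)cc3)c2)CC1` at 10 nM and compound 1 `O=C(Nc1cccc2cn[nH]c12)N1CCN(Cc2cccc(Oc3ccc(Cl)cc3)c2)CC1` at 1300 nM. Compound 4 `O=C(Nc1noc2cccnc12)N1CCN(Cc2cccc(Oc3ccc(Cl)cc3)c2)CC1` differs from compound 2 at a single place: a group of 9 heavy atoms (6 carbon, 2 nitrogen, 1 oxygen; one five-membered aromatic ring with 2 hetero atoms, one six-membered aromatic ring with 1 hetero atom) in place of a group of 10 heavy atoms (9 carbon, 1 nitrogen; one six-membered aromatic ring of carbon only, one six-membered aromatic ring with 1 hetero atom), on an amide-type nitrogen. The step most relevant to this change is a 1.5-fold higher number from compound 2 to compound 3 (0.17 log units; within the scatter), which shows that the five-membered ring with two hetero atoms fused to a carbon-only ring performs on a par with isoquinolin-4-yl in this assay. By contrast, a 190-fold lower number from compound 1 to compound 2 (2.29 log units; beyond the scatter) and a 130-fold lower number from compound 1 to compound 3 (2.11 log units; beyond the scatter) were large. Among the measured compounds shown here, no measured step tests adding a ring nitrogen to the six-membered ring, so the effect of that part of the change is unknown. Compound 4 is therefore expected to show a step of a 1.8-fold higher number from compound 2 to compound 4 (0.25 log units; within the scatter), with an estimated value of 12 nM, ranging from 4 nM to 40 nM.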

Compound 4, half-maximal inhibitory concentration: 13 nM
Compound 4: middle estimate off by 1.1-fold (0.03 log units), on the low side; measured number inside the range.
By their numbers in this assay, from the lowest: compounds 2, 3 and 4 (each within the scatter of the next); then compound 1.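

Among the compounds shown here, a six-membered aromatic ring with 1 hetero atom in the fused group, which no earlier step tested, keeps compound 4 level with its carbon-only counterpart: the result is a 1.3-fold higher number from compound 3 to compound 4 (0.11 log units; within the scatter) and stays within the scatter, as does a 1.9-fold higher number from compound 2 to compound 4 (0.29 log units; within the scatter). The new group also holds the large margin over the 1H-indazol-7-yl group, with a 100-fold lower number from compound 1 to compound 4 (2.00 log units; beyond the scatter). Going by these compounds, whether a single ring such as phenyl or pyridin-3-yl on the amide-type nitrogen would serve as well remains open. No evidence is available to explain the gap separating compound 1 from the other compounds.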